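The source may report more compounds than this note shows. Statements on the series, on what has been measured and on what is new or still open speak of the compounds shown alone.

Of the compounds shown here, two built on a shared core have been measured in a functional assay on CHO cells for positive allosteric modulation of muscarinic acetylcholine receptor M5 (Homo sapiens), read by FLIPR and calcium flux, with a stated time of 1 h; on this read-out lower numbers stand for an effect already at smaller amounts and higher numbers for an effect only at larger amounts of compound. Compound 1 `O=C1C(=O)N(Cc2ccc(Cl)nc2)c2ccc(OC(F)(F)F)cc21` gives 2400 nM in this assay. Compound 2 `COc1cccc(Oc2ccc(CN3C(=O)C(=O)c4cc(OC(F)(F)F)ccc43)cc2)n1` gives 2200 nM in this assay. Among the measured compounds shown here, the two numbers sit within the scatter of each other, so compound 2 cannot be told apart from compound 1 on this read-out, and no step between them is recorded.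

The next compound, compound 3 `O=C1C(=O)N(Cc2ccc(-c3ccncc3)cc2)c2ccc(OC(F)(F)F)cc21`, has not yet been measured. It differs from compound 2 in one place: pyridin-4-yl in place of (6-methoxypyridin-2-yl)oxy on an aromatic carbon. For the measured compounds named here, no step between measured compounds is known for this series, so nothing measured shows how such an exchange moves the number. Going by the values given here, the only guide is that compound 1 and compound 2, which differ considerably in the group carried by the shared core, still fall within the scatter of each other. On that slender basis, the step to compound 3 is expected to be none beyond the scatter, in either direction.

The step this expectation means, a 1.1-fold higher number from compound 2 to compound 3 (0.06 log units; within the scatter), is estimated to stay within the scatter. Compound 3 is therefore expected to give about 2500 nM, within a range from 800 nM to 8000 nM.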

Compound 3, half-maximal effective concentration: 2800 nM
The estimate for compound 3 lay 1.1-fold (0.05 log units) below the measured number; low and high end bracket the measured number.
By their numbers in this assay, from the lowest: compounds 2, 1 and 3 (each within the scatter of the next).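

In this assay, among the compounds shown here, pyridin-4-yl in place of (6-methoxypyridin-2-yl)oxy gives a 1.3-fold higher number from compound 2 to compound 3 (0.10 log units; within the scatter), the first step that can be read. At this place, on an aromatic carbon of a six-membered aromatic ring of carbon only, para to a large group, a change from 9 heavy atoms to 6 and from 3 hydrogen-bond acceptors to 1, with both oxygen atoms of the leaving group gone, does not separate the two compounds on this read-out. Nothing measured here accounts for this result.

The compounds shown leave open whether any group on this aromatic carbon can move the number beyond the scatter, since a single step within the scatter says nothing about groups of another kind, such as an amine, a carboxylic acid or a longer alkyl chain. They also leave open what the trifluoromethoxy group on the shared core contributes, as it stays the same in compound 1, compound 2 and compound 3.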